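The source may hold more compounds than are shown below. What is called first, only, known or untested is meant among the compounds shown, and "the series" means these compounds.

Measured compounds:
- compound 1 `Nc1ccccc1NC(=O)c1ccc(CSC(=S)N2CCc3cc([N+](=O)[O-])ccc32)cc1`: 43.6%
- compound 2 `Nc1ccccc1NC(=O)c1ccc(CSC(=S)N2CCN(C(c3ccccc3)c3ccccc3)CC2)cc1`: 13.8%
- compound 3 `CN(Cc1ccncc1)C(=S)SCc1ccc(C(=O)Nc2ccccc2N)cc1`: 72.7%

All three share one core and were tested in a functional assay on HeLa cells (Homo sapiens) for antiproliferative activity, read by CCK-8 assay, with a stated time of 72 h, tested at 8 uM; on this read-out lower numbers stand for a weaker effect and higher numbers for a stronger effect at the one concentration tested. Compound 3 gives the highest number of the three; compound 1 sits lower by a margin beyond the scatter, and compound 2 lower still. Compound 4 `CN1CCN(C(=S)SCc2ccc(C(=O)Nc3ccccc3N)cc2)CC1` has not yet been measured. It differs from compound 3 in one place: 4-methylpiperazin-1-yl in place of methyl((pyridin-4-yl)methyl)amino on a thiocarbonyl carbon. For the measured compounds named here, no step between measured compounds of this kind is known, so the expectation rests only on where compound 3 stands. The change is expected to cost some activity, a step of a number 22.7 percentage points lower from compound 3 to compound 4 (beyond the scatter) downward, likely beyond the scatter. Compound 4 is expected to give 50%, within a range from 25% to 72%.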

Compound 4, a percentage reported as inhibition, at one concentration (the size of the read-out at that concentration, not a potency): 75.7%
Compound 4: middle estimate off by 25.7 percentage points, on the low side; measured number outside the range, above it.
By their numbers in this assay, from the lowest: compound 2; then compound 1; then compounds 3 and 4 (each within the scatter of the next).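

In this assay the result is a number 3 percentage points higher from compound 3 to compound 4 (within the scatter) and so, on the thiocarbonyl carbon, 4-methylpiperazin-1-yl can stand in place of methyl((pyridin-4-yl)methyl)amino with no change beyond the scatter. In this pair, then, the six-membered aromatic ring of the group that leaves is not required to keep the read-out at this level. No available evidence explains why the two groups match. Still open, going by these compounds, is what the methyl group on the piperazine contributes, and whether an unsubstituted piperazine or a morpholine would match them here.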